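The source may report more compounds than this note shows. Statements on the series, on what has been measured and on what is new or still open speak of the compounds shown alone.

Compound 2, `O=c1cc(CSc2nc3ccccc3s2)oc2ccc(Cl)cc12`, is a close relative of compound 1, `O=c1cc(CSc2nc3ccccc3s2)oc2ccccc12`; the two share one core and differ only by a chloro group on an aromatic carbon. In a functional assay on LM7 cells (Homo sapiens) for cytotoxicity, read by MTT assay, with a stated time of 72 h (a higher number here means a weaker inhibitor, a lower number a stronger inhibitor), compound 1 gives only a limit of the assay, > 25000 nM. In this assay compound 2 likewise gives only a limit, > 25000 nM. The step that the two limits leave unreadable from compound 1 to compound 2 therefore cannot be read in size or direction, which is what the limit of > 25000 nM in this assay, at which 2 of the 2 values shown sit, records. Compound 2 thus stands at a limit rather than at a measured number.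

Compound 3, `Cc1ccc2oc(CSc3nc4ccccc4s3)cc(=O)c2c1`, has not yet been measured. It differs from compound 2 by methyl in place of chloro on an aromatic carbon. Going by the values given here, the only measured step touching this position is the one from compound 1 to compound 2, and that step is unreadable, so no measured step gives a direction for this assay. Compound 3 is therefore expected to stay at the same limit, with a step that the limit leaves unreadable from compound 2 to compound 3 expected to be no change beyond the scatter. For compound 3 the estimate in this assay is 30000 nM, with a range from 10000 nM to 100000 nM.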

Compound 3, half-maximal inhibitory concentration: > 25000 nM
Compound 3: only a limit was reported; the forecaster's own chance of this, stated with the estimate: 85%; the middle value does not contradict the limit.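

In this assay compound 3 also gives only a limit, so none of the steps among compound 1, compound 2 and compound 3 can be read in size or direction: the limit of > 25000 nM in this assay, at which 3 of the 3 values shown sit. The compounds shown leave open how strong any of the three is, and whether hydrogen, chloro or methyl on this aromatic carbon changes the result.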